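This account rests on a few compounds, and the source may have more. Where it says the series, first, only, none or still open, it means among the compounds named here.

Three fatty amides have been run in a functional assay on OVCAR-3 cells (Homo sapiens) for antiproliferative activity, read by sulforhodamine B assay, with a stated time of 48 h; on this read-out higher numbers stand for weaker inhibition of growth and lower numbers for stronger inhibition of growth. Compound 1 `CCCCCC[C@@H](O)C/C=C\CCCCCCCC(=O)N1CCOCC1` gives 31 ug/mL, compound 2 `CCCCCCCC/C=C\CCCCCCCC(=O)N1CCCCC1` gives 9.3 ug/mL, and compound 3 `CCCCCCCCCCCCCCCCCC(=O)N1CCCC1` gives 7.3 ug/mL. On these three numbers compound 2 stands second highest; its value and that of compound 3 lie within the scatter of each other, while compound 1 sits beyond the scatter above it.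

The step to compound 4 `CCCCC/C=C\C/C=C\CCCCCCCC(=O)N1CCCCC1` is one change on the chain: hept-1-en-1-yl in place of heptyl on a saturated chain carbon bound to a double-bonded chain carbon. Going by the values given here, no pair of measured compounds differs at this place alone, so nothing here shows what one further double bond does. Compound 4 is expected to stay close to compound 2, with the step of a 1.1-fold lower number from compound 2 to compound 4 (0.04 log units; within the scatter) not clearly beyond the scatter. The estimate for compound 4 is 8.5 ug/mL, within 4 ug/mL to 18 ug/mL.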

Compound 4, concentration for 50% growth inhibition: 48.9 ug/mL
Estimate against measurement, compound 4: 5.8-fold (0.76 log units) below, outside the stated range (above it).
By their numbers in this assay, from the lowest: compounds 3 and 2 (each within the scatter of the next); then compounds 1 and 4 (each within the scatter of the next).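

In this assay, hept-1-en-1-yl in place of heptyl on a saturated chain carbon bound to a double-bonded chain carbon gives a 5.3-fold higher number from compound 2 to compound 4 (0.72 log units; beyond the scatter). Going by these compounds alone, this is the first single-place step, and it shows that growth inhibition at this place of the chain responds to one added double bond, with a loss. No measurement here bears on the origin of that loss.

As far as these compounds go, whether the loss carries over to a longer chain with the same added double bond remains open. So does the effect of a carboxylic acid in place of the amide.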